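The source may report more compounds than this note shows. Statements on the series, on what has been measured and on what is new or still open speak of the compounds shown alone.

In a functional assay on the whole organism (strain albino) with Mus musculus as the target, with a stated time of 0.5 h (a higher number here means that more compound is needed for the effect, a lower number that less compound is needed), compound 3 `O=C(CCCN1C(=O)c2ccccc2C1=O)Nc1ccc(F)cc1F` gives 100 mg/kg, the lowest number among the three measured compounds: compound 1 `O=C(CCCN1C(=O)c2ccccc2C1=O)Nc1ccc(F)cc1` gives 300 mg/kg and compound 2 `O=C(CCCN1C(=O)c2ccccc2C1=O)Nc1ccc(Cl)cc1Cl` gives 300 mg/kg. Compound 4 `Cc1cc(Cl)ccc1NC(=O)CCCN1C(=O)c2ccccc2C1=O` arises from compound 3 through the change (4-chloro-2-methylphenyl in place of 2,4-difluorophenyl on an amide-type nitrogen). The step of a 3.0-fold lower number from compound 2 to compound 3 (0.48 log units; beyond the scatter) bears most directly on this change, since it also exchanges one 2,4-disubstituted phenyl for another on the amide-type nitrogen; the step of a 3.0-fold lower number from compound 1 to compound 3 (0.48 log units; beyond the scatter) likewise ends at compound 3. Both were modest. Replacing the 2,4-difluorophenyl of compound 3 with a chlorine-bearing ring is expected to give back that advantage, so compound 4 is estimated at 300 mg/kg, between 100 mg/kg and 1000 mg/kg, a step of a 3.0-fold higher number from compound 3 to compound 4 (0.48 log units; beyond the scatter) toward a higher number.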

Compound 4, minimum effective dose: 300 mg/kg
For compound 4 middle estimate and measured number coincide at the digits printed; the measured number falls inside the stated range.
By their numbers in this assay, from the lowest: compound 3; then compounds 1, 2 and 4 (each within the scatter of the next).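

In this assay, 4-chloro-2-methylphenyl in place of 2,4-difluorophenyl on the amide-type nitrogen gives a 3.0-fold higher number from compound 3 to compound 4 (0.48 log units; beyond the scatter), so this new ring does not keep the edge of compound 3. Methyl in place of chloro on an aromatic carbon gives no change at the digits printed from compound 2 to compound 4 (within the scatter), and 4-chloro-2-methylphenyl in place of 4-fluorophenyl gives no change at the digits printed from compound 1 to compound 4 (within the scatter). Three different rings thus read alike and only 2,4-difluorophenyl stands apart, and nothing at hand accounts for this. On these data alone, whether a ring carrying methoxy, trifluoromethyl or an amine would match compound 3 remains open.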